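Triazole aryl swap: hydroxymethylphenyl gives way to nitrophenyl

The compounds below may be only part of what the source reports. "The series", "measured", "known", "first", "only" and "open" are said of these compounds alone.

Measured compounds:
Compound 1 `COc1ccccc1-n1cc(COc2c(/C=C\C(=O)O)ccc(OC)c2CC=C(C)C)nn1` gives 12200 nM in a functional assay on COLO 205 cells (Homo sapiens) for cytotoxicity, read by MTT assay, with a stated time of 24 h; on this read-out higher numbers stand for weaker inhibition and lower numbers for stronger inhibition.
Compound 2 `COc1ccc(-n2cc(COc3c(/C=C\C(=O)O)ccc(OC)c3CC=C(C)C)nn2)cc1` has no result in this assay: "not determined" (no result reported).
Compound 3 `COc1ccc(/C=C\C(=O)O)c(OCc2cn(-c3ccc(CO)cc3)nn2)c1CC=C(C)C` gives 19300 nM in this assay.

For the measured compounds named here, of the two numbers reported, the number of compound 3 is the one reached by the step of a 1.6-fold higher number from compound 1 to compound 3 (0.20 log units; within the scatter); that step lies within the scatter, so compounds 1 and 3 cannot be separated on this read-out, and compound 2 contributes no number.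

Compound 4 `COc1ccc(/C=C\C(=O)O)c(OCc2cn(-c3cccc([N+](=O)[O-])c3)nn2)c1CC=C(C)C` differs from compound 3 in one place: 3-nitrophenyl in place of 4-(hydroxymethyl)phenyl on an aromatic nitrogen. Going by the values given here, no measured step involves a nitrophenyl group. Among the compounds with values here, the only step that bears on the same position is a 1.6-fold higher number from compound 1 to compound 3 (0.20 log units; within the scatter), and it shows that exchanging one aryl group for another on the ring nitrogen left the number within the scatter. On that basis no step beyond the scatter is expected from compound 3 to compound 4, in either direction.

Compound 4 is therefore estimated to give 15000 nM in this assay, within a range from 6000 nM to 40000 nM. The expected step is a 1.3-fold lower number from compound 3 to compound 4 (0.11 log units; within the scatter).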

Compound 4, half-maximal inhibitory concentration: 6900 nM
Estimate against measurement, compound 4: 2.2-fold (0.34 log units) above; low and high end bracket the measured number.
By their numbers in this assay, from the lowest: compounds 4, 1 and 3 (each within the scatter of the next, the first and the last beyond it).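

For the compounds shown here, the aryl group on the aromatic nitrogen can shift the number in this assay beyond the scatter: 3-nitrophenyl in place of 4-(hydroxymethyl)phenyl gives a 2.8-fold lower number from compound 3 to compound 4 (0.45 log units; beyond the scatter) and is the first step at this position to clear it, though only modestly. The exchange of 2-methoxyphenyl for 3-nitrophenyl gives a 1.8-fold lower number from compound 1 to compound 4 (0.25 log units; within the scatter) and stays within the scatter, so the effect of this position rests on a single pair, with the 2-methoxyphenyl compound not separable from either member. Nothing measured here explains the step between the hydroxymethyl and nitro compounds.

Steps to or from compound 2 cannot be read, as it has no number in this assay and so cannot show how a methoxy group placed elsewhere on the ring compares. From the compounds shown here alone, it also remains open whether the step follows from gaining the nitro group or from losing the hydroxymethyl group, and whether an amine on the phenyl ring in place of the nitro group, or an unsubstituted phenyl, would hold the lower number.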